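Dropping the nitroso group from a cytotoxic nucleoside urea

The compounds below may be only part of what the source reports. "The series", "measured", "known", "first", "only" and "open" are said of these compounds alone.

Compound 1 `CN(N=O)C(=O)N[C@H]1[C@@H](O)[C@H](n2ccc(N)nc2=O)O[C@@H]1CO` is one of two measured nucleoside ureas. In a functional assay on HEp-2 cells (Homo sapiens) for cytotoxicity (a lower number here means that less compound is needed, a higher number that more compound is needed for the effect), compound 1 gives only a limit, > 50 uM. Compound 2 `CN(N=O)C(=O)N[C@H]1[C@@H](O)[C@H](n2ccc(=O)[nH]c2=O)O[C@@H]1CO` likewise reaches only a limit in this assay, > 60 uM. Compound 1 therefore stands at the limit of > 50 uM in this assay, at which 1 of the 2 values shown sits, without a number of its own. Compound 3 `CNC(=O)N[C@H]1[C@@H](O)[C@H](n2ccc(N)nc2=O)O[C@@H]1CO` carries a hydrogen atom in place of a group of 2 heavy atoms (1 nitrogen, 1 oxygen; no ring), on an amide-type nitrogen. For the measured compounds named here, no measured pair shows this change, so the step in this assay from compound 1 to compound 3 is expected to be none beyond the scatter or a move toward more compound needed. The expected step is a step that the limit leaves unreadable from compound 1 to compound 3. Compound 3 is estimated at 100 uM, between 30 uM and 400 uM.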

Compound 3, concentration for half-maximal effect: > 60 uM
Compound 3: no number, only a limit (the forecaster's own chance of this, stated with the estimate: 85%); the middle value is on the limit's open side.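

Compound 1 and compound 3 both give only limits in this assay and the step between them cannot be read. The compounds shown leave open how much of either is needed for the effect, and whether a hydrogen atom in place of the nitroso group changes that amount.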